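Cationic amidine tail on the piperazine of compound 2

The source may report more compounds than this note shows. Statements on the series, on what has been measured and on what is new or still open speak of the compounds shown alone.

Compound 1 `Cc1cc(C)c2cccc(OCc3c(Cl)ccc(S(=O)(=O)NC4(C(=O)N5CCN(C(=O)CCC[N+](C)(C)C)CC5)CCCC4)c3Cl)c2n1` gives in an assay on isolated protein for binding affinity to B1 bradykinin receptor (Homo sapiens) (a higher number here means a weaker inhibitor, a lower number a stronger inhibitor), only a limit, < 10000 nM. Compound 2 `Cc1cc(C)c2cccc(OCc3c(Cl)ccc(S(=O)(=O)NC4(C(=O)N5CCN(C(=O)[C@@H](N)CCC[N+](C)(C)C)CC5)CCCC4)c3Cl)c2n1` likewise gives in this assay only a limit, < 10000 nM; the step that the two limits leave unreadable from compound 1 to compound 2 cannot be read because of the limit of < 10000 nM in this assay, at which 2 of the 2 values shown sit. Compound 3 `Cc1cc(C)c2cccc(OCc3c(Cl)ccc(S(=O)(=O)NC4(C(=O)N5CCN(C(=N)NCCC[N+](C)(C)C)CC5)CCCC4)c3Cl)c2n1` differs from compound 2 by a group of 10 heavy atoms (7 carbon, 3 nitrogen; no ring) in place of a group of 11 heavy atoms (8 carbon, 2 nitrogen, 1 oxygen; no ring), on an amine nitrogen in a ring. For the measured compounds named here, no measured step bears on this change, and the two limits give no size to compare. Compound 3 is therefore expected to stay near compound 2, with a step that the limit leaves unreadable from compound 2 to compound 3 taken as no shift beyond the scatter. The estimate for compound 3 in this assay is 1500 nM, between 100 nM and 10000 nM.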

Compound 3, inhibition constant: < 10000 nM
Compound 3 gave a limit, no number; the forecaster's own chance of this, stated with the estimate: 65%; the middle value does not contradict the limit.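

For the compounds shown here, no step between compound 1, compound 2 and compound 3 can be read, because all three results are limits: the limit of < 10000 nM in this assay, at which 3 of the 3 values shown sit. The compounds shown leave open what actual value each of the three has, and whether the groups that differ among them shift it at all.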